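Bromo in place of hydrogen on compound 1

A few compounds are considered here, and "the series" means these few. Any claim that something is new, unique, unknown or untested is made for them only; others in the source may bear on it.

Within the data shown here, in a functional assay on HeLa cells (Homo sapiens) for antiproliferative activity, read by MTT assay, with a stated time of 48 h (on this read-out lower numbers stand for stronger inhibition of growth and higher numbers for weaker inhibition of growth), compound 1 `COc1ccc(/C=C2\Cc3c(cc(OC)c(OC)c3OC)C2=O)cc1` gives 485 nM, the only actual number so far. Compound 2 `COc1cc2c(c(OC)c1OC)C/C(=C\c1cc(OC)c(OC)c(OC)c1OC)C2=O` gives only a limit of the assay, > 10000 nM. Compound 3 `COc1ccc(/C=C2\Cc3c(cc(OC)c(OC)c3OC)C2=O)cc1Br` keeps the core of compound 1 with one change: bromo in place of hydrogen on an aromatic carbon. Among the measured compounds shown here, no measured pair shows this change, so the expectation rests on compound 1 alone. In this assay no shift beyond the usual scatter is expected, and the estimated move is a 1.2-fold lower number from compound 1 to compound 3 (0.08 log units; within the scatter). For compound 3 the estimated value is 400 nM, with an expected range of 100 nM to 2500 nM.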

Compound 3, concentration for 50% growth inhibition: 356 nM
The estimate for compound 3 lay 1.1-fold (0.05 log units) above the measured number, within the range that was stated.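

In this assay, among these compounds, bromo in place of hydrogen on this aromatic carbon, ortho to a methoxy group and meta to a large group, gives a 1.4-fold lower number from compound 1 to compound 3 (0.13 log units; within the scatter) and is the first readable step. The position therefore accepts one bromine atom with no shift beyond the scatter, and compound 3 stays clear of the assay limit.

On these data alone, whether an amine or a carboxylic acid at this carbon would leave the read-out equally unchanged remains open. No measured property explains this result.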